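Benzyloxycarbonyl for 3-phenylpropyl at a tolerance limit

A few compounds are considered here, and "the series" means these few. Any claim that something is new, unique, unknown or untested is made for them only; others in the source may bear on it.

In an ADME assay on MT2 cells (Homo sapiens) for cytotoxicity, read by XTT assay, with a stated time of 4 days (a lower number here means that less compound is tolerated, a higher number that more compound is tolerated), compound 1 (`Cc1ccc(-c2c3c(nc(C)c2C(OC(C)(C)C)C(=O)O)CCN(Cc2ccccc2-c2ccccc2)C3)cc1`) gives > 40000 nM and this reading is a limit, not a number. Compound 2 (`Cc1ccc(-c2c3c(nc(C)c2[C@H](OC(C)(C)C)C(=O)O)CCN(CCCc2ccccc2)C3)cc1`) gives > 40000 nM in this assay and this too is only a limit. The record so far therefore consists of the limit of > 40000 nM in this assay, at which 2 of the 2 values shown sit, and compound 2 cannot be ranked against compound 1.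

Compound 3 (`Cc1ccc(-c2c3c(nc(C)c2[C@H](OC(C)(C)C)C(=O)O)CCN(C(=O)OCc2ccccc2)C3)cc1`) carries one change from compound 2: benzyloxycarbonyl in place of 3-phenylpropyl on an amine nitrogen in a ring with the rest of the structure the same. Within the data shown here, no measured step between two closely matched compounds is available, so the size of such a change in this assay has no direct precedent. The expectation rests on compound 2 and its limit of > 40000 nM and on compound 1, which shows the same limit. The expected step of a number no higher from compound 2 to compound 3 (the limit leaves the size open) is none beyond the usual scatter, in either direction. For compound 3 the estimate is 40000 nM with an expected range from 20000 nM to 80000 nM and the assay may well report only a limit again.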

Compound 3, half-maximal cytotoxic concentration: > 40000 nM
Compound 3 gave a limit, no number (the forecaster's own chance of this, stated with the estimate: 75%); the middle value lies on the limit itself.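

Compound 2 and compound 3 both end at a limit in this assay, so the step between them cannot be read. The compounds shown leave open the concentration at which any of them becomes cytotoxic, and whether benzyloxycarbonyl in place of 3-phenylpropyl makes any difference to it: the limit of > 40000 nM in this assay, at which 3 of the 3 values shown sit.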